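The compounds below may be only part of what the source reports. "The series", "measured", "known", "first", "only" and "open" are said of these compounds alone.

Compound 1 `CC1=C(/C=C/C(=O)/C=C/c2cccc(C(F)(F)F)c2)C(C)(C)CCC1O` gives 740 nM in a functional assay on LNCaP cells (Homo sapiens) for cytotoxicity, read by MTT assay, with a stated time of 72 h; on this read-out lower numbers stand for stronger inhibition and higher numbers for weaker inhibition.
Compound 2 `CC1=C(/C=C/C(=O)/C=C/c2cc(C(F)(F)F)ccc2C(F)(F)F)C(C)(C)CCC1O` gives 3200 nM in this assay.
Compound 3 `CC1=C(/C=C/C(=O)/C=C/c2ccc(F)c(C(F)(F)F)c2)C(C)(C)CCC1O` gives 2200 nM in this assay.

Compound 1 stands lowest of the three numbers. Its nearest neighbour is compound 3, reached by a 3.0-fold higher number from compound 1 to compound 3 (0.47 log units; beyond the scatter), and the furthest is compound 2, reached by a 4.3-fold higher number from compound 1 to compound 2 (0.64 log units; beyond the scatter). Compound 4 `CC1=C(/C=C/C(=O)/C=C/c2cccc(C#N)c2)C(C)(C)CCC1O` has not yet been measured. It differs from compound 1 by cyano in place of trifluoromethyl on an aromatic carbon. Among the measured compounds shown here, no measured pair shows this same exchange. The two measured steps each add a group to compound 1 and each raise the number beyond the scatter, but neither removes or replaces the trifluoromethyl, so they bear on the present step only loosely. On that basis a small step upward in this assay is expected for compound 4, of a size near the edge of the scatter, and with a wide range given the lack of a direct precedent. Compound 4 is estimated at 1500 nM, expected to fall between 500 nM and 4500 nM, which corresponds to a 2.0-fold higher number from compound 1 to compound 4 (0.31 log units; beyond the scatter).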

Compound 4, half-maximal inhibitory concentration: 1800 nM
Compound 4: middle estimate off by 1.2-fold (0.08 log units), on the low side, within the range that was stated.
By their numbers in this assay, from the lowest: compound 1; then compounds 4, 3 and 2 (each within the scatter of the next).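

Compound 4 is the only one shown in which the trifluoromethyl itself is exchanged, whereas the earlier steps kept it and added a group to the aromatic ring. In this assay, among the compounds shown here, the exchange for cyano at this place, meta to a large group, gives a 2.4-fold higher number from compound 1 to compound 4 (0.39 log units; beyond the scatter) and so shows that the trifluoromethyl cannot be swapped for cyano without a modest loss, though the loss is no larger than the steps seen on adding a group. Nothing measured here explains this difference.

The compounds shown leave open whether any other group at this place, such as a methoxy group, an amine or a carboxylic acid, would match or better the trifluoromethyl. From the compounds shown here alone, they also leave open how the unsubstituted aromatic ring would compare, so the value of having any group here at all remains unknown.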